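Clearance when only the configuration changes

A few compounds are considered here, and "the series" means these few. Any claim that something is new, unique, unknown or untested is made for them only; others in the source may bear on it.

Measured in an ADME assay on the whole organism (strain Sprague-Dawley) for pharmacokinetics, with Rattus norvegicus as the target, using cassette dosing; a higher number here means faster removal of the compound, a lower number slower removal:
compound 1 `O=c1[nH]c2ccc(-c3cc(C[C@]4(O)CC[C@@H](Cc5ccc(Cl)cc5)CC4)no3)cc2o1`: "not determined" (no result reported)
compound 2 `O=c1ccc(-c2cc(C[C@]3(O)CC[C@@H](Cc4ccccc4)CC3)no2)c[nH]1`: 37.6 mL/min/kg
compound 3 `O=c1ccc(-c2cc(C[C@]3(O)CC[C@@H](Cc4ccc(Cl)cc4)CC3)no2)c[nH]1`: 16.8 mL/min/kg

Of the two compounds with a number, compound 3 stands lowest, at 16.8 mL/min/kg. Compound 4 `O=c1ccc(-c2cc(C[C@]3(O)CC[C@H](Cc4ccc(Cl)cc4)CC3)no2)c[nH]1` differs from it as follows: the two compounds have the same atoms and bonds and differ only in configuration as drawn: 2 of 2 stereo elements differ (all stereocentres are inverted: mirror images); a stereocentre at a saturated ring carbon is drawn s in compound 3 and r in compound 4; a stereocentre at a saturated ring carbon is drawn s in compound 3 and r in compound 4. Nothing leaves and nothing enters, so the change lies only in the configuration as drawn at the saturated ring carbons.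

For the measured compounds named here, the only measured step, a 2.2-fold lower number from compound 2 to compound 3 (0.35 log units; beyond the scatter), is chloro in place of hydrogen on an aromatic carbon. It is modest but beyond the scatter. Going by the values given here, it shows that this assay can respond to a single small change, but no measured pair differs in configuration alone. That step therefore gives neither a size nor a direction for this one, and the expectation stays anchored on compound 3 at 16.8 mL/min/kg.

The expected result, with no firm direction, is a 1.1-fold higher number from compound 3 to compound 4 (0.03 log units; within the scatter). Compound 4 is estimated at 18 mL/min/kg, with an expected range of 8 mL/min/kg to 40 mL/min/kg.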

Compound 4, clearance: 6.6 mL/min/kg
Beside the measured number, compound 4's estimate is 2.7-fold (0.44 log units) above it; the measured number lies below the stated range.
By their numbers in this assay, from the lowest: compound 4; then compound 3; then compound 2.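

In this assay, inverting the configuration at the saturated ring carbons gives a 2.5-fold lower number from compound 3 to compound 4 (0.41 log units; beyond the scatter). This shows that the read-out responds to configuration alone, which the earlier step, a 2.2-fold lower number from compound 2 to compound 3 (0.35 log units; beyond the scatter), could not show. Both steps are modest and both run toward a lower number, and the newer one can be laid on configuration alone because nothing else separates the pair: the fact that compounds 3 and 4 differ only in the configuration as drawn

From the compounds shown here alone, compound 2, which lacks the chloro group, appears in one configuration only, so whether the same inversion would lower its number remains open, and the core of compound 1 carries no number to compare in either configuration. The compounds shown also leave open how a fluoro or methoxy group in place of the chloro would behave in either configuration.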